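A few compounds are considered here, and "the series" means these few. Any claim that something is new, unique, unknown or untested is made for them only; others in the source may bear on it.

Series of purine analogues tested in a functional assay on SW-620 cells (Homo sapiens) for inhibition; on this read-out lower numbers stand for stronger inhibition and higher numbers for weaker inhibition.

Compound 1 `CC(O)n1cnc2c(N)nc(I)nc21` carries a free hydroxyl on the side chain. In this assay compound 1 gives > 500000 nM, which is a limit of the assay rather than a number. Compound 2 `CC(=O)OC(C)n1cnc2c(N)nc(I)nc21` is its acetate; in this assay compound 2 gives > 500000 nM, again only a limit. The step that the two limits leave unreadable from compound 2 to compound 1 is therefore not readable in size; the change is hydrogen in place of acetyl on an oxygen on a saturated carbon.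

Compound 3 `CC(=O)OC(C)n1cnc2c(S)nc(F)nc21` has a different core; how its core differs from that of compound 2 is not broken down here. In this assay compound 3 gives > 500000 nM, a limit. All three values sit at the limit of > 500000 nM in this assay, at which 3 of the 3 values shown sit.

Compound 4 `CC(O)n1cnc2c(S)nc(F)nc21` is the corresponding alcohol, the same change as before: hydrogen in place of acetyl on an oxygen on a saturated carbon. Because compound 3 sits at the limit of > 500000 nM in this assay, at which 3 of the 3 values shown sit, compound 4 is expected to give 500000 nM in this assay, plausibly between 200000 nM and 1000000 nM, a step of a number no higher from compound 3 to compound 4 (the limit leaves the size open) that is an estimate only.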

Compound 4, half-maximal inhibitory concentration: > 500000 nM
Compound 4 ended at the assay's limit (the forecaster's own chance of this, stated with the estimate: 85%); the middle value sits exactly at the limit.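

No step can be read from compound 3 to compound 4, as both sit at a limit rather than a number: the limit of > 500000 nM in this assay, at which 4 of the 4 values shown sit.

The compounds shown leave open whether acetoxy to hydroxy, or the difference in core, changes anything in this assay.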